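Swapping the Trifluoro Alcohol for a Methyl Alcohol

The source may hold more compounds than are shown below. What is called first, only, known or untested is meant among the compounds shown, and "the series" means these compounds.

Within the data shown here, compound 2 `Nc1cc(C(F)(F)F)c(Br)nc1C(=O)NC[C@H](O)C(F)(F)F` gives 23 nM in an assay on CHO cells for positive allosteric modulation of Cystic fibrosis transmembrane conductance regulator variant F508del (Homo sapiens), using a membrane potential dye, with a stated time of 30 min, in the presence of a further agent that is not named here (a higher number here means that more compound is needed for the effect, a lower number that less compound is needed), the lowest of the two numbers measured so far, while compound 1 `CC(O)CNC(=O)c1nc(Br)c(C(F)(F)F)cc1N` gives 70 nM. Among the measured compounds shown here, the only measured change at the same position is a 3.0-fold lower number from compound 1 to compound 2 (0.48 log units; beyond the scatter). Compound 3 `CC(C)(O)CNC(=O)c1nc(Br)c(C(F)(F)F)cc1N` carries 1-hydroxy-1-methylethyl in place of 2,2,2-trifluoro-1-hydroxyethyl on a saturated chain carbon bound to an amide-type nitrogen. That earlier step is largely undone here, so a rise of similar size is expected, namely a 2.8-fold higher number from compound 2 to compound 3 (0.45 log units; beyond the scatter). Compound 3 is therefore estimated at 65 nM in this assay, with a plausible range from 25 nM to 170 nM.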

Compound 3, half-maximal effective concentration: 77 nM
Compound 3: the middle estimate sits 1.2-fold (0.07 log units) below what was measured; the measured number falls inside the stated range.
By their numbers in this assay, from the lowest: compound 2; then compounds 1 and 3 (each within the scatter of the next).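

In this assay the change from 2,2,2-trifluoro-1-hydroxyethyl to 1-hydroxy-1-methylethyl gives a 3.3-fold higher number from compound 2 to compound 3 (0.52 log units; beyond the scatter), so the added methyl does not match the gain seen with the three fluorines. Adding that methyl to the chain of the first compound gives a 1.1-fold higher number from compound 1 to compound 3 (0.04 log units; within the scatter), which leaves the two methyl-bearing alcohols level. No measurement here gives a reason for either result. As far as these compounds go, the share of the defined stereocentre of compound 2 in its lower number stays open. So does the outcome with an amine or a carboxylic acid in place of the alcohol.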